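The source may report more compounds than this note shows. Statements on the series, on what has been measured and on what is new or still open speak of the compounds shown alone.

Three hydrazide-type compounds built on the same naphthyloxyacetyl core have been examined in an ADME assay on HEL cells (Homo sapiens) for cytotoxicity; on this read-out higher numbers stand for lower toxicity in this test and lower numbers for higher toxicity in this test. Compound 1 `C/C(=N\NC(=O)COc1cccc2ccccc12)c1ccc(C#N)cc1Br` gives 12.7 ug/mL in this assay, the lowest of the three numbers. Compound 2 `O=C(COc1cccc2ccccc12)N/N=C/c1cccc([N+](=O)[O-])c1` gives 61.2 ug/mL in this assay, and compound 3 `O=C(COc1cccc2ccccc12)N/N=C/C=C/c1ccccc1` gives 100 ug/mL in this assay. Both of these values lie beyond the usual scatter above the value of compound 1, so compound 1 shows the highest toxicity of the three in this test.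

Compound 4 `C/C(=N\NC(=O)COc1cccc2ccccc12)c1ccccc1` has not yet been measured in this assay. It differs from compound 1 in one place: phenyl in place of 2-bromo-4-cyanophenyl on a carbon with a double bond to nitrogen

Among the compounds with values here, no two of the measured compounds differ in only one place, so no directly comparable step is available. Still, compound 1 stands apart from its neighbours, and the step to compound 4 removes the bromine and the nitrile from the aryl group. The estimated step of a 2.8-fold higher number from compound 1 to compound 4 (0.44 log units; beyond the scatter) is expected to move the number upward and beyond the scatter, toward the region occupied by compound 2 with its 61.2 ug/mL. Compound 4 is therefore estimated at 35 ug/mL in this assay, within a range from 15 ug/mL to 90 ug/mL.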

Compound 4, half-maximal cytotoxic concentration: 20 ug/mL
For compound 4 the middle estimate is 1.8-fold (0.24 log units) above the measured one, within the range that was stated.
By their numbers in this assay, from the lowest: compounds 1 and 4 (each within the scatter of the next); then compounds 2 and 3 (each within the scatter of the next).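

Within the data shown here, the first step that changes only one place shows that, in this assay, exchanging 2-bromo-4-cyanophenyl for phenyl on a carbon with a double bond to nitrogen gives a 1.6-fold higher number from compound 1 to compound 4 (0.20 log units; within the scatter), so compound 1 and compound 4 cannot be told apart in this test. With the bromine and the nitrile both gone and the rest of the structure unchanged, compound 4 gives 20 ug/mL and remains within the scatter of compound 1, so the number of compound 1 cannot be tied to these two substituents taken together. Nothing measured alongside this step offers an explanation for it.

The compounds shown leave open whether the bromine alone or the nitrile alone would give a number within the scatter of compound 1 and compound 4, as the two groups leave together in this one step. They also leave open whether an amine or a carboxylic acid on the phenyl ring of compound 4, or a longer chain in place of the saturated chain carbon at this position, would shift the number beyond the scatter.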